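Ethyl to butyl: a longer chain, an expected step

This account rests on a few compounds, and the source may have more. Where it says the series, first, only, none or still open, it means among the compounds named here.

Measured so far:
Compound 1, `N#C[Se]c1ccc(NC(=O)OCc2ccccc2)cc1`, gives 73700 nM in a functional assay on CCRF-CEM cells (Homo sapiens) for cytotoxicity, read by MTT assay, with a stated time of 72 h; a higher number here means that more compound is tolerated, a lower number that less compound is tolerated.
Compound 2, `CCOC(=O)Nc1ccc([Se]C#N)cc1`, gives 68800 nM in this assay.

Within the data shown here, compound 2 holds the lowest of the two numbers seen, yet its only neighbour, compound 1, sits within the scatter of it, so the two cannot be told apart. Among the measured compounds shown here, the one measured step, a 1.1-fold lower number from compound 1 to compound 2 (0.03 log units; within the scatter), exchanged the group on the saturated chain carbon bound to an oxygen next to a carbonyl group and left the number essentially where it was. Compound 3, `CCCCOC(=O)Nc1ccc([Se]C#N)cc1`, is yet to be measured. It differs from compound 2 as follows: ethyl in place of hydrogen on a saturated chain carbon, two bonds along the chain from an oxygen next to a carbonyl group. The earlier step bears on this one only loosely, since it altered the same region of the molecule without moving the number beyond the scatter. No step beyond the scatter is therefore expected, and the value for compound 3 is estimated at 65000 nM, between 30000 nM and 140000 nM. That corresponds to an expected step of a 1.1-fold lower number from compound 2 to compound 3 (0.02 log units; within the scatter).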

Compound 3, concentration lethal to 50% of the cells in the CCRF-CEM assay: 63500 nM
The estimate for compound 3 lay 1.0-fold (0.01 log units) above the measured number; low and high end bracket the measured number.
By their numbers in the CCRF-CEM assay, from the lowest: compounds 3, 2 and 1 (each within the scatter of the next).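

Ethyl in place of hydrogen at this position leaves the CCRF-CEM assay without a readable change: the result is a 1.1-fold lower number from compound 2 to compound 3 (0.03 log units; within the scatter), and the comparison with the phenyl-bearing compound gives a 1.2-fold lower number from compound 1 to compound 3 (0.06 log units; within the scatter). Among these compounds, all three end groups on this chain therefore give numbers that cannot be told apart in this cell assay, and this holds across a wider range of groups than the single earlier step could show. The same change does register on another read-out: in a physicochemical assay, with a stated time of 6 min, tested at 0.1 mg/mL (on this read-out higher numbers stand for more inhibition at the one concentration tested (going by the name of the read-out) and lower numbers for less inhibition), compound 2 gives 26.3% and compound 3 gives 12.6%, a modest change, a number 13.7 percentage points lower from compound 2 to compound 3 (beyond the scatter).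

On these data alone, it remains open whether an amine or a carboxylic acid on this chain would move the number in the CCRF-CEM assay beyond the scatter. The compounds shown also cannot say why this change registers on one read-out and not on the other.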